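Notes on the ring swap from compound 3 to compound 4

This account rests on a few compounds, and the source may have more. Where it says the series, first, only, none or still open, it means among the compounds named here.

Measured compounds:
compound 1 `CC(C)(C)c1ccc(/C(=C\CC(N)C(=O)O)c2ccc(F)cc2F)cc1`: > 10000 nM
compound 2 `Cc1ccc(/C(=C\CC(N)C(=O)O)c2ccc(F)cc2F)cc1`: 9560 nM
compound 3 `CCc1ccc(/C(=C\CC(N)C(=O)O)c2ccc(F)cc2F)cc1`: > 10000 nM

In a functional assay for inhibition of sodium- and chloride-dependent glycine transporter 1 (Rattus norvegicus), with a stated time of 30 min, in the presence of a further agent that is not named here (on this read-out higher numbers stand for weaker inhibition and lower numbers for stronger inhibition), compound 1 gives only a limit, > 10000 nM. Compound 2 gives 9560 nM in this assay. Compound 3 returns only a limit in this assay, > 10000 nM, so it stands at the limit of > 10000 nM in this assay, at which 2 of the 3 values shown sit, and no number is known for it.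

The three measured steps, an at least 1.0-fold lower number from compound 1 to compound 2 (0.01 log units; that floor lies within the scatter), a step that the two limits leave unreadable from compound 1 to compound 3 and an at least 1.0-fold higher number from compound 2 to compound 3 (0.01 log units; that floor lies within the scatter), all concern the alkyl group on the phenyl ring and none of them moves beyond the scatter or can be read at all. Compound 4 `NC(C/C=C(\c1ccsc1)c1ccc(F)cc1F)C(=O)O` differs from compound 3 by thiophen-3-yl in place of 4-ethylphenyl on a double-bonded chain carbon bound to an aromatic carbon and a double-bonded chain carbon. For the measured compounds named here, no measured step changes the ring itself, so the earlier steps do not bear on this change directly; they show only that the whole set sits at or near the limit. Compound 4 is therefore expected to stay weak, with an estimated 7000 nM in this assay, between 1500 nM and 25000 nM, meaning an expected step of an at least 1.4-fold lower number from compound 3 to compound 4 (0.15 log units; that floor lies within the scatter).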

Compound 4, half-maximal inhibitory concentration: > 10000 nM
Compound 4: no number, only a limit; the forecaster's own chance of this, stated with the estimate: 40%; at least 1.4-fold (0.15 log units) between middle value and limit.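

Thiophen-3-yl on the double-bonded chain carbon is the only change of the ring itself in this set, and in this assay compound 4 gives > 10000 nM, which is a limit and not a number. For the compounds shown here, the one readable step is an at least 1.0-fold higher number from compound 2 to compound 4 (0.01 log units; that floor lies within the scatter), while the steps between two limits cannot be read. The five-membered ring with sulfur therefore shows no readable gain over the six-membered carbon ring at this place, and compound 4 sits with compound 1 and compound 3: the limit of > 10000 nM in this assay, at which 3 of the 4 values shown sit.

On these data alone, compound 3 and compound 4 carry limits only, so the true size of the ring change stays open. Also open, as far as these compounds go, is whether a pyridine ring or a phenyl ring bearing an amine at this place would give a number in this assay.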